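A Methyl Step Repeated on a Rearranged Core

A few compounds are considered here, and "the series" means these few. Any claim that something is new, unique, unknown or untested is made for them only; others in the source may bear on it.

Of the compounds shown here, three have been measured in an ADME assay on BHK-21 cells (Mesocricetus auratus) for cytotoxicity, read by MTT assay, with a stated time of 96 h; on this read-out lower numbers stand for higher toxicity in this test and higher numbers for lower toxicity in this test. Compound 1 `Cc1ccc(/N=N/c2ccc(NCCCN(C)C)cc2)cc1` reaches only a limit of the assay, giving > 100000 nM in this assay, as the limit of > 100000 nM in this assay, at which 1 of the 3 values shown sits, records. Compound 2 `CN(C)CCCNc1ccc(/N=N/c2ccccc2)cc1` gives 31000 nM in this assay, and compound 3 `CN(C)CCCN(/N=N/c1ccccc1)c1ccccc1` gives 50000 nM in this assay; these two values lie within the usual scatter of each other, so no order between them can be read. Compound 2 and compound 3 are built from the same atoms joined differently, and the difference between the two cores is not broken down here.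

From compound 2 to compound 1 the change is methyl in place of hydrogen on an aromatic carbon, and it produced an at least 3.2-fold higher number from compound 2 to compound 1 (0.50 log units; beyond the scatter).

Compound 4 `Cc1ccc(/N=N/N(CCCN(C)C)c2ccccc2)cc1` is not yet measured. It differs from compound 3 by methyl in place of hydrogen on an aromatic carbon, the same change, at a place described in the same words. Because the earlier step gave an at least 3.2-fold higher number from compound 2 to compound 1 (0.50 log units; beyond the scatter) and compound 3 gives 50000 nM, compound 4 is expected to show a 3.0-fold higher number from compound 3 to compound 4 (0.48 log units; beyond the scatter) in this assay. Compound 4 is therefore estimated at 150000 nM in this assay, between 60000 nM and 400000 nM.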

Compound 4, half-maximal cytotoxic concentration: > 100000 nM
Compound 4: no number, only a limit (the forecaster's own chance of this, stated with the estimate: 60%); the middle value does not contradict the limit.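

In this assay compound 4 gives > 100000 nM, which is a limit of the assay and not a number. The methyl change on this second core gives an at least 2.0-fold higher number from compound 3 to compound 4 (0.30 log units; that floor lies within the scatter), so the result fits the direction seen on the first core, but this floor alone does not show a step beyond the scatter. The data therefore show that the two results are compatible, not that the change carries over with the same size, and two cores are too few to make a rule for the series: the same change on two cores in this assay, an at least 3.2-fold higher number (0.50 log units; beyond the scatter) from compound 2 to compound 1 and an at least 2.0-fold higher number (0.30 log units; that floor lies within the scatter) from compound 3 to compound 4; the limit leaves it open whether they differ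

The compounds shown leave open how far past the limit of the assay compound 1 and compound 4 lie, so a lower test concentration range or a wider one would be needed to size either step. They also leave open whether a group other than methyl in the same place, such as ethyl, chlorine or an amine, would move the read-out on either core.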